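This account rests on a few compounds, and the source may have more. Where it says the series, first, only, none or still open, it means among the compounds named here.

Compound 1 `CCCCC(=O)Nc1ccn([C@@H]2CO[C@H](CO)O2)c(=O)n1` — 5230 nM
Compound 2 `CCCCCCC(=O)Nc1ccn([C@@H]2CO[C@H](CO)O2)c(=O)n1` — 1040 nM

In a functional assay on A549 cells (Homo sapiens) for cytotoxicity, read by sulforhodamine B assay, with a stated time of 72 h (a higher number here means a weaker inhibitor, a lower number a stronger inhibitor), compound 2 gives the lowest of the two numbers; its nearest neighbour is compound 1 with 5230 nM. Compound 3 `CCCCCCCCC(=O)Nc1ccn([C@@H]2CO[C@H](CO)O2)c(=O)n1` differs from compound 2 by ethyl in place of hydrogen on a saturated chain carbon, six bonds along the chain from a carbonyl carbon. Among the measured compounds shown here, one measured step bears on this: a 5.0-fold lower number from compound 1 to compound 2 (0.70 log units; beyond the scatter), the same kind of lengthening, placed four bonds along the chain from the carbonyl carbon rather than six. A further lowering is therefore expected, and the expected step is a 2.6-fold lower number from compound 2 to compound 3 (0.41 log units; beyond the scatter), smaller than the measured one. Compound 3 is estimated at 400 nM, with a range of 150 nM to 1500 nM.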

Compound 3, half-maximal inhibitory concentration: 46 nM
Estimate against measurement, compound 3: 8.7-fold (0.94 log units) above; the whole stated range lies above it.
By their numbers in this assay, from the lowest: compound 3; then compound 2; then compound 1.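

In this assay the ethyl in place of hydrogen, six bonds along the chain from a carbonyl carbon, gives a 23-fold lower number from compound 2 to compound 3 (1.35 log units; beyond the scatter) and so outdoes the same change at four bonds: the second lengthening counts for more than the first. Taken whole, butyl in place of hydrogen gives a 110-fold lower number from compound 1 to compound 3 (2.06 log units; beyond the scatter) and no levelling off appears across these three compounds. Nothing measured here says why the step grows. As far as these compounds go, whether a longer chain lowers the number further or turns it back up stays open, as does whether a chain ending in an amine or a carboxylic acid would keep the gain.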